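This account rests on a few compounds, and the source may have more. Where it says the series, first, only, none or still open, it means among the compounds named here.

Of the compounds shown here, three of one series have been measured in a functional assay on MCF7 cells (Homo sapiens) for cytotoxicity, read by MTT assay, with a stated time of 72 h; on this read-out lower numbers stand for stronger inhibition and higher numbers for weaker inhibition. Compound 1 `O=C(CCl)Nc1ccc(C(=O)/C=C/c2ccc([N+](=O)[O-])cc2)cc1` gives 3910 nM. Compound 2 `O=C(CSC(=S)N[C@H]1CCOC1=O)Nc1ccc(C(=O)/C=C/c2ccc(Cl)cc2)cc1` gives 20300 nM, and compound 3 `O=C(CSC(=S)N[C@H]1CCOC1=O)Nc1ccc(C(=O)/C=C/c2ccc(Br)cc2)cc1` gives 18700 nM. On these numbers compound 3 stands second highest of the three: compound 2 lies nearest to it, within the scatter, while compound 1 lies furthest away, with a number lower than that of compound 3 by a margin beyond the scatter. For the measured compounds named here, the only single-place step among the measured compounds is a 1.1-fold lower number from compound 2 to compound 3 (0.04 log units; within the scatter), an exchange of one halogen for another on the outer ring that left the read-out essentially unchanged.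

Compound 4 `O=C(CSC(=S)N[C@H]1CCOC1=O)Nc1ccc(C(=O)/C=C/c2ccc([N+](=O)[O-])cc2)cc1` differs from compound 3 in one place: nitro in place of bromo on an aromatic carbon. Going by the values given here, no measured step covers this exchange directly. Among the compounds with values here, compound 1 carries the same nitro group, but it also differs from compound 4 elsewhere, so its number cannot be read as a step for this change; it shows only that a nitro-bearing member of the series can reach a lower number. Given that the halogen exchange from compound 2 to compound 3 stayed within the scatter, the author expects for compound 4 a step of a 1.3-fold lower number from compound 3 to compound 4 (0.13 log units; within the scatter) in this assay, most likely within the scatter, with a modest lean towards a lower number. For compound 4 the estimate in this assay is 14000 nM, with a range from 5500 nM to 40000 nM.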

Compound 4, half-maximal inhibitory concentration: 2670 nM
Estimate against measurement, compound 4: 5.2-fold (0.72 log units) above; the whole stated range lies above it.
By their numbers in this assay, from the lowest: compounds 4 and 1 (each within the scatter of the next); then compounds 3 and 2 (each within the scatter of the next).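

In this assay, the aromatic carbon para to a large group proves sensitive to what it carries: nitro in place of bromo gives a 7.0-fold lower number from compound 3 to compound 4 (0.85 log units; beyond the scatter), and nitro in place of chloro gives a 7.6-fold lower number from compound 2 to compound 4 (0.88 log units; beyond the scatter). The earlier exchange of one halogen for the other, a 1.1-fold lower number from compound 2 to compound 3 (0.04 log units; within the scatter), had shown no such movement, so the flat result for chloro and bromo does not extend to every group at this position. With nitro held in place, the other end of the molecule makes no clear difference: the step is a 1.5-fold lower number from compound 1 to compound 4 (0.17 log units; within the scatter), so replacing the chlorine on the saturated chain carbon bound to a carbonyl carbon with the larger group leaves the read-out within the scatter.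

Nothing available bears on what lies behind the nitro step. As far as these compounds go, it remains open whether a nitrile, a methoxy group, an amine or a carboxylic acid at this position would follow nitro or the halogens, and whether the chlorine on the chain carbon would match the larger group as closely with chloro or bromo on the outer ring.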